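The source may hold more compounds than are shown below. What is called first, only, known or untested is meant among the compounds shown, and "the series" means these compounds.

Measured compounds in a functional assay on A-375 cells (Homo sapiens) for antiproliferative activity, read by CCK-8 assay, with a stated time of 72 h, tested at 2 uM; on this read-out higher numbers stand for a stronger effect at the one concentration tested and lower numbers for a weaker effect:
compound 1 `Nc1ccccc1NC(=O)c1ccc(CSC(=S)N2CCN(c3ccccc3)CC2)cc1`, 27.5%
compound 2 `CN(C(=S)SCc1ccc(C(=O)Nc2ccccc2N)cc1)c1cccnc1`, 26.5%
compound 3 `CC1CCCCN1C(=S)SCc1ccc(C(=O)Nc2ccccc2N)cc1`, 42.5%

On these numbers compound 1 stands second of three: its number and that of compound 2 lie within the scatter of each other, while compound 3 sits higher by an amount beyond the scatter. Within the data shown here, the only measured step, a number 16 percentage points higher from compound 2 to compound 3 (beyond the scatter), alters the group on the thiocarbonyl carbon, not the ring nitrogen changed here, so it does not bear directly on the present change. Compound 4 `Nc1ccccc1NC(=O)c1ccc(CSC(=S)N2CCN(Cc3cccnc3)CC2)cc1` differs from compound 1 by (pyridin-3-yl)methyl in place of phenyl on an amine nitrogen in a ring. Among the measured compounds shown here, no measured pair tests this exchange; compound 2, which carries a pyridin-3-yl elsewhere, gives a number within the scatter of compound 1. No step beyond the scatter is therefore expected: a number 2.5 percentage points higher from compound 1 to compound 4 (within the scatter). Compound 4 is estimated at 30%, between 15% and 50%.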

Compound 4, a percentage reported as inhibition, at one concentration (the size of the read-out at that concentration, not a potency): 31.5%
Compound 4: the middle estimate sits 1.5 percentage points below what was measured; measured number inside the range.
By their numbers in this assay, from the lowest: compounds 2, 1 and 4 (each within the scatter of the next); then compound 3.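

In this assay, (pyridin-3-yl)methyl in place of phenyl on the amine nitrogen in the ring gives a number 4 percentage points higher from compound 1 to compound 4 (within the scatter). Among these compounds, this is the first direct test of this position, and it shows that the larger group, with its hydrogen-bond acceptor, leaves the read-out within the usual scatter. No measurement shown here offers an explanation for this result.

Among the compounds shown here, the single step changes both the ring and its link to the nitrogen, so their separate contributions remain open. Also open, as far as these compounds go, is how a benzyl group or a carboxylic acid at this nitrogen would compare.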